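The compounds below may be only part of what the source reports. "The series", "measured", "known", "first", "only" and "open" are said of these compounds alone.

Measured compounds:
compound 1, `CCc1ccc(Nc2cc(NC(=O)Nc3c(Cl)cccc3Cl)ncn2)cc1`, in a functional assay on NCI-H520 cells (Homo sapiens) for inhibition, read by MTT assay, with a stated time of 48 h, tested at 10 uM (a lower number here means less inhibition, a higher number more inhibition at the concentration tested (going by the name of the read-out)), compound 1 gives 31.5%
compound 2, `CCc1cccc(Nc2cc(NC(=O)Nc3cc(OC)cc(OC)c3)ncn2)c1`, compound 2 gives 23%
compound 3, `COc1cc(Nc2cc(NC(=O)Nc3c(Cl)cccc3Cl)ncn2)cc(C(F)(F)F)c1`, compound 3 gives 23.1%

All three numbers lie within the usual scatter of one another, so compound 2 stands level with compound 3 and compound 1; the series shows no step beyond the scatter so far.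

Compound 4, `COc1cc(NC(=O)Nc2cc(Nc3ccc(Br)cc3OC)ncn2)cc(OC)c1`, is not yet measured. It differs from compound 2 in one place: 4-bromo-2-methoxyphenyl in place of 3-ethylphenyl on a nitrogen on an aromatic ring. The change sits on a nitrogen on an aromatic ring whose other neighbours are aromatic carbon, while the rest of the molecule is kept. For the measured compounds named here, with no measured step to rest on, the expectation is a step of no more than the scatter in this assay, in either direction. Compound 4 is therefore estimated at 27% (range 10% to 48%), an expected step of a number 4 percentage points higher from compound 2 to compound 4 (within the scatter).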

Compound 4, a percentage reported as inhibition, at one concentration (the size of the read-out at that concentration, not a potency): 36.1%
For compound 4 the middle estimate is 9.1 percentage points below the measured one; the measured number falls inside the stated range.
By their numbers in this assay, from the lowest: compounds 2, 3, 1 and 4 (each within the scatter of the next, the first and the last beyond it).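

In this assay, for the compounds shown here, the group on a nitrogen on an aromatic ring gives the first readable step: 4-bromo-2-methoxyphenyl in place of 3-ethylphenyl produces a number 13.1 percentage points higher from compound 2 to compound 4 (beyond the scatter) with the rest of the molecule kept. Going by these compounds alone, this place therefore responds to a change of group, though only one pair supports that. Nothing available explains the step.

On these data alone, the bromine and the methoxy enter together, so the share of each stays open. Also open, as far as these compounds go, is how this place would respond to an amine or a carboxylic acid on the ring.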